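Amide to urea on a pyrazole scaffold against melanoma cells

This account rests on a few compounds, and the source may have more. Where it says the series, first, only, none or still open, it means among the compounds named here.

Measured compounds:
compound 1, `O=C(Nc1cccc(-n2cc(-c3ccncc3)c(-c3ccc(Cl)c(O)c3)n2)c1)Nc1cccc(C(F)(F)F)c1`, 9580 nM
compound 2, `COc1cc(-c2nn(-c3cccc(NC(=O)c4cccc(C(F)(F)F)c4)c3)cc2-c2ccncc2)ccc1Cl`, only a limit

In a functional assay on LOX IMVI cells (Homo sapiens) for inhibition, read by sulforhodamine B assay, with a stated time of 48 h (a lower number here means a stronger inhibitor of growth, a higher number a weaker inhibitor of growth), compound 1 gives 9580 nM. For compound 2 the assay reports only a limit, > 50000 nM, and not a number; it sits at the limit of > 50000 nM in this assay, at which 1 of the 2 values shown sits. Compound 2 therefore stands at the weak end of what is shown, with compound 1 the only one carrying a measured value.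

Compound 3, `COc1cc(-c2nn(-c3cccc(NC(=O)Nc4cccc(C(F)(F)F)c4)c3)cc2-c2ccncc2)ccc1Cl`, is not yet measured. It differs from compound 2 by (3-(trifluoromethyl)phenyl)amino in place of 3-(trifluoromethyl)phenyl on a carbonyl carbon. Within the data shown here, compound 1 carries that same group on its carbonyl carbon and returns a number rather than a limit, so a move in the stronger direction is expected, though no measured step between two compounds describes this change directly. Compound 3 is thus expected to reach about 20000 nM, within 5000 nM to 50000 nM, an estimated step of an at least 2.5-fold lower number from compound 2 to compound 3 (0.39 log units; beyond the scatter).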

Compound 3, concentration for total growth inhibition: 1650 nM
The estimate for compound 3 lay 12-fold (1.08 log units) above the measured number, outside the stated range (below it).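

In this assay, (3-(trifluoromethyl)phenyl)amino in place of 3-(trifluoromethyl)phenyl on a carbonyl carbon, with nothing else changed, gives an at least 30-fold lower number from compound 2 to compound 3 (1.48 log units; beyond the scatter). Compound 2 holds a limit and not a number, so the size of this step is only a bound: the limit of > 50000 nM in this assay, at which 1 of the 3 values shown sits. Among the ureas, methyl in place of hydrogen on an oxygen on an aromatic ring gives a 5.8-fold lower number from compound 1 to compound 3 (0.76 log units; beyond the scatter), so this position also counts, which the earlier compounds could not show.

The compounds shown leave open whether the change from amide to urea would act the same way with hydrogen rather than methyl on that oxygen, since the only amide here carries the methyl. They also do not tell how an ethyl group on that oxygen, or a chlorine in place of the trifluoromethyl, would read in this assay.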